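The source may hold more compounds than are shown below. What is called first, only, known or untested is meant among the compounds shown, and "the series" means these compounds.

Measured in an ADME assay on microsomes from liver (Mus musculus) for pharmacokinetics, read by LC-MS, using NADPH, with stated times of 5 min, 15 min and 30 min, tested at 10 uM; a higher number here means faster removal of the compound, a lower number slower removal:
Compound 1 `C[C@H](NC(=O)[C@@H]1CCCN1C)c1ccc(NC(=O)N2CC(c3cccnc3)C2)cc1`: 40.8 mL.min-1.g-1.
Compound 2 `C[C@H](NC(=O)[C@@H]1CCCN1C)c1ccc(NC(=O)N2CC(c3ccc(N)nc3)C2)cc1`: < 25 mL.min-1.g-1, which is a limit of the assay and not a number.
Compound 3 `C[C@H](NC(=O)c1cccc(F)c1)c1ccc(NC(=O)N2CC(c3cncc(N)c3)C2)cc1`: 27.4 mL.min-1.g-1.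

The two true numbers lie within the scatter of each other: compound 3 gives 27.4 mL.min-1.g-1 and compound 1 gives 40.8 mL.min-1.g-1. Compound 4 `C[C@H](NC(=O)[C@@H]1CCCN1C)c1ccc(NC(=O)N2CC(c3cncc(N)c3)C2)cc1` differs from compound 3 as follows: 1-methylpyrrolidin-2-yl in place of 3-fluorophenyl on a carbonyl carbon. Among the measured compounds shown here, no measured step makes this exchange. The nearest guide is a different change, amino in place of hydrogen on an aromatic carbon, an at least 1.6-fold lower number from compound 1 to compound 2 (0.21 log units; that floor lies within the scatter). Compound 2 carries both the amino group and the entering group, so no step beyond the scatter is expected in this assay. The expected change is a 1.0-fold lower number from compound 3 to compound 4 (0.01 log units; within the scatter). For compound 4 the estimated value is 27 mL.min-1.g-1, with an expected range of 15 mL.min-1.g-1 to 45 mL.min-1.g-1.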

Compound 4, intrinsic clearance in microsomes: 47.4 mL.min-1.g-1
Compound 4: middle estimate off by 1.8-fold (0.24 log units), on the low side; measured number outside the range, above it.
By their numbers in this assay, from the lowest: compounds 3, 1 and 4 (each within the scatter of the next). At a limit, below all of these: compound 2.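

In this assay, the exchange on the carbonyl carbon can now be read directly: 1-methylpyrrolidin-2-yl in place of 3-fluorophenyl gives a 1.7-fold higher number from compound 3 to compound 4 (0.24 log units; within the scatter). Adding the amino group to the pyridine in its 5-aminopyridin-3-yl form gives a 1.2-fold higher number from compound 1 to compound 4 (0.07 log units; within the scatter), so neither step clears the scatter. Taking 5-aminopyridin-3-yl in place of 6-aminopyridin-3-yl gives an at least 1.8-fold higher number from compound 2 to compound 4 (0.27 log units; that floor lies within the scatter), a step that starts from a limit and not a number: the limit of < 25 mL.min-1.g-1 in this assay, at which 1 of the 4 values shown sits.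

As far as these compounds go, the true number for compound 2 remains open. So does how a longer chain ending in an amine would behave on this carbonyl carbon.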